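The compounds below may be only part of what the source reports. "The series", "measured", "known", "first", "only" and "open" are said of these compounds alone.

Measured compounds:
- compound 1, `CC(C)(C)Cc1c(-c2ccc(F)cc2)sc(N)c1C(=O)c1ccc(Cl)cc1` — 1%
- compound 2, `CC(C)(C)Cc1c(-c2cc(F)ccc2F)sc(N)c1C(=O)c1ccc(Cl)cc1` — 3%
- compound 3, `CC(C)(C)Cc1c(-c2c(F)cccc2F)sc(N)c1C(=O)c1ccc(Cl)cc1` — 1%

All three share one core and differ only in the fluorine pattern of the aryl group on the thiophene carbon that carries it. In an assay on CHO cells for displacement of a labelled ligand from adenosine receptor A1 (Homo sapiens), read by scintillation counting, tested at 10 uM (on this read-out higher numbers stand for more inhibition at the one concentration tested (going by the name of the read-out) and lower numbers for less inhibition), compound 1 gives 1% and compound 2 gives 3%; the step of a number 2 percentage points higher from compound 1 to compound 2 (within the scatter) lies within the scatter. Compound 3 is level with compound 1 at the digits shown, the step of no change at the digits printed from compound 1 to compound 3 (within the scatter) being no change, and against compound 2 the step of a number 2 percentage points lower from compound 2 to compound 3 (within the scatter) is again within the scatter. The three numbers therefore sit together, and no pattern among them can be read.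

The next compound, compound 4, `CC(C)(C)Cc1c(-c2ccc(Cl)c(Cl)c2)sc(N)c1C(=O)c1ccc(Cl)cc1`, changes the same aryl group: 3,4-dichlorophenyl in place of 2,6-difluorophenyl on an aromatic carbon. Going by the values given here, none of the measured steps exchanges fluorine for chlorine, so the only bearing they have is that three different fluorine patterns on this ring left this assay unchanged within the scatter. On that basis the expected step is a number 2 percentage points higher from compound 3 to compound 4 (within the scatter), none beyond the scatter. Compound 4 is accordingly estimated at 3%, with a range from 0% to 15%.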

Compound 4, a percentage reported as inhibition, at one concentration (the size of the read-out at that concentration, not a potency): 1%
Estimate against measurement, compound 4: 2 percentage points above; low and high end bracket the measured number.
By their numbers in this assay, from the lowest: compounds 1, 3, 4 and 2 (each within the scatter of the next).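

Notes on the aryl position: the exchange of fluorine for chlorine on this aromatic carbon, next to the ring sulfur, is new to the series, and in this assay the 3,4-dichlorophenyl group gives no change at the digits printed from compound 3 to compound 4 (within the scatter) and a number 2 percentage points lower from compound 2 to compound 4 (within the scatter) and no change at the digits printed from compound 1 to compound 4 (within the scatter) as its three readings against the fluorinated analogues. The flat picture at this position therefore no longer rests on fluorine patterns alone: a phenyl group carrying two chlorines sits with the 4-fluorophenyl, 2,5-difluorophenyl and 2,6-difluorophenyl groups, and all four compounds stay within the scatter of one another, close to no inhibition at the one concentration tested. Nothing measured bears on why this position shows no response to the change.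

Every aryl group shown here is a halogen-substituted phenyl, so it remains open whether a non-halogen substituent on that ring, such as a carboxylic acid or a dimethylamino group, would shift the reading. The neopentyl group, the (4-chlorophenyl)carbonyl group and the amino group are the same throughout, which leaves open what a shorter chain such as ethyl, or an acetamide in place of the amino group, would do.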